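A few compounds are considered here, and "the series" means these few. Any claim that something is new, unique, unknown or untested is made for them only; others in the source may bear on it.

Measured so far:
- compound 1 `O=C(Nc1ccc(Cl)c(-c2nnc3c(Cl)cccn23)c1)c1cccnc1`: > 100000 nM in a functional assay on T47D cells (Homo sapiens) for antiproliferative activity, read by MTT assay, with a stated time of 72 h; a higher number here means a weaker inhibitor, a lower number a stronger inhibitor
- compound 2 `O=C(Nc1ccc(Cl)c(-c2nnc3c(Cl)cccn23)c1)c1ccc(C(F)(F)F)cc1F`: 70800 nM in this assay

Compound 1 stands only at a limit in this assay: the value > 100000 nM is a limit of the assay, not a number, as the limit of > 100000 nM in this assay, at which 1 of the 2 values shown sits, records. Compound 2, with a different aryl group on the carbonyl, gives 70800 nM, so compound 2 too sits in the very weak range of this assay, and the two values show no separation that can be stated.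

Compound 3 `O=C(Nc1ccc(Cl)c(-c2nnc3c(Cl)cccn23)c1)c1ccccc1` differs from compound 1 at one place: phenyl in place of pyridin-3-yl on a carbonyl carbon. Within the data shown here, no measured step covers this kind of exchange. The expectation for this assay is a step of no more than the scatter, perhaps a slight move toward a lower number, so that compound 3 is expected to land near the limit again. Compound 3 is estimated at 90000 nM, with a range from 30000 nM to 300000 nM. The step from compound 1 that this estimate means is expected to be an at least 1.1-fold lower number from compound 1 to compound 3 (0.04 log units; that floor lies within the scatter).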

Compound 3, half-maximal inhibitory concentration: > 100000 nM
Compound 3 was reported as a limit; the forecaster's own chance of this, stated with the estimate: 55%; middle value at least 1.1-fold (0.04 log units) away from the limit.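

In this assay, compound 1 and compound 3 both stand at a limit of the assay and not at a number, so no step between them can be read, because both sit at the same limit: the limit of > 100000 nM in this assay, at which 2 of the 3 values shown sit.

The compounds shown leave open whether phenyl in place of pyridin-3-yl on a carbonyl carbon moves the read-out in this assay at all.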